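Methyl on the terminal phenyl and liver-cell cytotoxicity

The source may hold more compounds than are shown below. What is called first, only, known or untested is meant among the compounds shown, and "the series" means these compounds.

Compound 1 `O=c1[nH]cc(S(=O)(=O)Nc2ccccc2-c2cn(-c3ccccc3)nn2)c(=O)[nH]1` stands as the lowest of the two numbers recorded so far. In an ADME assay on L02 cells (Homo sapiens) for cytotoxicity, read by MTT assay, with a stated time of 24 h (on this read-out higher numbers stand for lower toxicity in this test and lower numbers for higher toxicity in this test), compound 1 gives 10600 nM. Its nearest neighbour is compound 2 `Cc1ccccc1-n1cc(-c2ccccc2NS(=O)(=O)c2c[nH]c(=O)[nH]c2=O)nn1`, which in this assay gives 56600 nM, so that a 5.3-fold higher number from compound 1 to compound 2 (0.73 log units; beyond the scatter). Compound 3 `Cc1cccc(-n2cc(-c3ccccc3NS(=O)(=O)c3c[nH]c(=O)[nH]c3=O)nn2)c1` has not yet been measured in this assay. It differs from compound 1 by methyl in place of hydrogen on an aromatic carbon, which cut one bond further out reads phenyl to 3-methylphenyl. For the measured compounds named here, the only step that bears on it is a 5.3-fold higher number from compound 1 to compound 2 (0.73 log units; beyond the scatter), which carries the same group onto the same ring but at another place; no measured step puts the group meta to a large group. A rise of the number, smaller and less certain than that one, is therefore expected, a 2.4-fold higher number from compound 1 to compound 3 (0.37 log units; beyond the scatter). Compound 3 is estimated to give 25000 nM in this assay, within a range from 8000 nM to 80000 nM.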

Compound 3, half-maximal cytotoxic concentration: 21900 nM
Estimate against measurement, compound 3: 1.1-fold (0.06 log units) above; the range from low to high includes it.
By their numbers in this assay, from the lowest: compound 1; then compound 3; then compound 2.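

With the methyl on the terminal phenyl now meta to a large group, this assay still shows a rise, a 2.1-fold higher number from compound 1 to compound 3 (0.32 log units; beyond the scatter), so the higher number is not confined to the 2-methylphenyl compound. The place of the methyl also matters, since moving it gives a 2.6-fold lower number from compound 2 to compound 3 (0.41 log units; beyond the scatter), and 2-methylphenyl therefore stands highest of the three. Nothing available explains this order or why either methyl raises the number.

From the compounds shown here alone, whether an amine, a carboxylic acid or a longer chain in place of the methyl would move the number in the same direction remains open. So does whether a methyl on another ring of the shared core would raise the number at all.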